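The source may hold more compounds than are shown below. What is called first, only, known or untested is meant among the compounds shown, and "the series" means these compounds.

Measured so far in a functional assay on A-431 cells (Homo sapiens) for antiproliferative activity, read by CCK-8 assay, with a stated time of 72 h; a lower number here means a stronger inhibitor, a higher number a weaker inhibitor:
compound 1, `Cc1cc(Nc2cc(N3CCN(C)CC3)nc(Nc3cccc(Cl)c3)n2)n[nH]1`: 87.5 nM
compound 2, `Cc1cc(Nc2cc(N3CCN(C)CC3)nc(Nc3ccc(Cl)cc3)n2)n[nH]1`: 162 nM

For the measured compounds named here, compound 2 has the higher of the two numbers in this assay; its only neighbour is compound 1, and the step of a 1.9-fold higher number from compound 1 to compound 2 (0.27 log units; within the scatter) does not rise above the scatter, so the two compounds read as equivalent on the present data.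

Compound 3, `Cc1cc(Nc2cc(N3CCN(C)CC3)nc(Nc3ccc(C#N)cc3)n2)n[nH]1`, is not yet measured. It differs from compound 2 in one place: cyano in place of chloro on an aromatic carbon, that is, 4-chlorophenyl becomes 4-cyanophenyl, and (4-chlorophenyl)amino becomes (4-cyanophenyl)amino.

Going by the values given here, the one measured step, from compound 1 to compound 2, moves the chloro substituent around the ring; it does not exchange chloro for cyano, so it speaks to the change into compound 3 only indirectly, by showing that altering this phenyl ring left the number within the scatter. Among the compounds with values here, no measured pair exchanges one substituent for another on this ring.

On that basis the step into compound 3 is expected to be small, estimated at a 1.2-fold higher number from compound 2 to compound 3 (0.09 log units; within the scatter), with no direction that the data can support. Compound 3 is accordingly estimated at 200 nM in this assay, within a range of 70 nM to 600 nM.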

Compound 3, half-maximal inhibitory concentration: 140 nM
Compound 3: middle estimate off by 1.4-fold (0.15 log units), on the high side, within the range that was stated.
By their numbers in this assay, from the lowest: compounds 1, 3 and 2 (each within the scatter of the next).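

In this assay, for the compounds shown here, cyano in place of chloro on this aromatic carbon gives a 1.2-fold lower number from compound 2 to compound 3 (0.06 log units; within the scatter), the first exchange of one substituent for another on this phenyl ring, and the step stays within the scatter. On the present numbers, 4-chlorophenyl and 4-cyanophenyl therefore read as equivalent here, even though cyano carries 2 heavy atoms and 1 hydrogen-bond acceptor where chloro carries 1 heavy atom and none. The comparison with the other chloro isomer gives a 1.6-fold higher number from compound 1 to compound 3 (0.20 log units; within the scatter), also within the scatter, so all three phenyl rings shown read as equivalent, and no information on the cause of this is available.

Still open, going by these compounds, is whether this flat response extends to substituents of a different kind on the same aromatic carbon, such as an amine, a carboxylic acid or a longer chain, and whether the unsubstituted phenyl or 3-cyanophenyl would read the same. All three compounds also share the rest of the core, so the sensitivity of the number to changes elsewhere in the molecule remains undefined.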